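Iodine in place of bromine on the nitrile-bearing ring

The source may report more compounds than this note shows. Statements on the series, on what has been measured and on what is new or still open speak of the compounds shown alone.

Of the compounds shown here, three sharing one core have been measured in a functional assay on HEK293 cells for antagonist activity at metabotropic glutamate receptor 5 (Rattus norvegicus), read by calcium flux; a lower number here means a stronger inhibitor, a higher number a weaker inhibitor. Compound 1 `Cc1nc(C#Cc2cc(C#N)cc([N+](=O)[O-])c2)cs1` gives 2.63 nM, compound 2 `Cc1nc(C#Cc2cc(Cl)cc(C#N)c2)cs1` gives 1.61 nM, and compound 3 `Cc1nc(C#Cc2cc(Br)cc(C#N)c2)cs1` gives 1.06 nM. Compound 3 and compound 2 are not separated, since the step of a 1.5-fold lower number from compound 2 to compound 3 (0.18 log units; within the scatter) lies within the scatter; the step of a 2.5-fold lower number from compound 1 to compound 3 (0.39 log units; beyond the scatter) is beyond it, so compound 3 stands apart from compound 1 but not from compound 2.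

Compound 4 `Cc1nc(C#Cc2cc(I)cc(C#N)c2)cs1` differs from compound 3 in one place: iodo in place of bromo on an aromatic carbon.

The step that bears on this change is the earlier exchange of one halogen for another, a 1.5-fold lower number from compound 2 to compound 3 (0.18 log units; within the scatter), which stayed within the scatter. The exchange a 1.6-fold lower number from compound 1 to compound 2 (0.21 log units; within the scatter) also stayed within it. A halogen-for-halogen swap has therefore not moved the number beyond the scatter so far, and for compound 4 no step beyond the scatter is expected in this assay, perhaps a slight drift downward, a 1.2-fold lower number from compound 3 to compound 4 (0.07 log units; within the scatter). Compound 4 is expected to give about 0.9 nM, within a range from 0.4 nM to 2 nM.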

Compound 4, half-maximal inhibitory concentration: 1.05 nM
For compound 4 the middle estimate is 1.2-fold (0.07 log units) below the measured one, within the range that was stated.
By their numbers in this assay, from the lowest: compounds 4, 3, 2 and 1 (each within the scatter of the next, the first and the last beyond it).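

In this assay the halogen on this aromatic carbon, meta to a cyano group, can be taken as far as iodo with no visible effect: the exchange for bromo gives a 1.0-fold lower number from compound 3 to compound 4 (0.00 log units; within the scatter) and the exchange for chloro gives a 1.5-fold lower number from compound 2 to compound 4 (0.19 log units; within the scatter) so chloro, bromo and iodo are not separated here. The exchange for nitro gives a 2.5-fold lower number from compound 1 to compound 4 (0.40 log units; beyond the scatter) and lies beyond the scatter, yet this is no clean divide between halogens and nitro, since the chloro compound, compound 2, is not separated from compound 1. Nothing available explains why these exchanges leave the number where it is.

Still open, as far as these compounds go, is whether fluoro, the one common halogen absent here, would fit the same level. Also open, from the compounds shown here alone, is what an amine, a carboxylic acid or a methoxy group would do on this carbon.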